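This account rests on a few compounds, and the source may have more. Where it says the series, first, only, none or still open, it means among the compounds named here.

In an ADME assay on TERT-RPE1 cells (Homo sapiens) for cytotoxicity, read by MTT assay, with a stated time of 72 h (on this read-out higher numbers stand for weaker inhibition and lower numbers for stronger inhibition), compound 1 `COc1ccc(/C=C2\S/C(=N\c3ccc(C)c(Cl)c3)N(C)C2=O)cc1` gives 23000 nM. Compound 2 `COc1ccc(/C=C2\S/C(=N\c3c(C)cccc3C)N(C)C2=O)cc1` reads > 100000 nM, which is a limit of the assay. Compound 3 `COc1ccc(/C=C2\S/C(=N\c3ccccc3)N(C)C2=O)cc1` reads > 100000 nM, also a limit and not a number, so it stands at the limit of > 100000 nM in this assay, at which 2 of the 3 values shown sit. Compound 4 `COc1ccc(/C=C2\S/C(=N\c3ccc(OC)cc3)N(C)C2=O)cc1` has methoxy in place of hydrogen on an aromatic carbon, para to a large group: methoxy in place of hydrogen on an aromatic carbon. Among the compounds with values here, two measured steps bear on this change. One is an at least 4.3-fold higher number from compound 1 to compound 3 (0.63 log units; beyond the scatter), and the other is an at least 4.3-fold higher number from compound 1 to compound 2 (0.63 log units; beyond the scatter). Compound 2 is substituted yet sits at the limit, so it goes against any rule that substitution alone lowers the number. Only a modest move toward a lower number, or none beyond the scatter, is therefore expected in this assay. The expected change is an at least 1.4-fold lower number from compound 3 to compound 4 (0.15 log units; that floor lies within the scatter). For compound 4 the estimate is 70000 nM, with an expected range from 20000 nM to 150000 nM.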

Compound 4, half-maximal inhibitory concentration: > 100000 nM
Compound 4: only a limit was reported (the forecaster's own chance of this, stated with the estimate: 55%); middle value at least 1.4-fold (0.15 log units) away from the limit.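

In this assay, methoxy on the aromatic carbon para to a large group leaves compound 4 at a limit, not a number: the limit of > 100000 nM in this assay, at which 3 of the 4 values shown sit. A second substituted phenyl thus stays at the limit, and 3-chloro-4-methylphenyl remains the only group shown that gives a number, with 4-methoxyphenyl in its place giving an at least 4.3-fold higher number from compound 1 to compound 4 (0.63 log units; beyond the scatter). The steps to compound 4 from compound 2 and compound 3 join two limits and cannot be read.

From the compounds shown here alone, whether methoxy changes the read-out at all stays open. So does whether chlorine or methyl alone on the phenyl, or an amine or carboxylic acid there, would give a number.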